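The source may hold more compounds than are shown below. What is called first, only, known or untested is meant among the compounds shown, and "the series" means these compounds.

In a functional assay on Vero cells (Chlorocebus sabaeus) for cytotoxicity (a lower number here means that less compound is tolerated, a higher number that more compound is tolerated), compound 3 `COC(=O)C(O)Cn1cnc2c(N)ncnc21` gives > 400 ug/mL, which is a limit of the assay rather than a number. Compound 1 `CCOC(=O)C(O)Cn1cnc2c(N)ncnc21` likewise gives > 400 ug/mL there, again a limit. Compound 2 `Nc1ncnc2c1ncn2CC(O)C(=O)OCc1ccco1` gives 40 ug/mL in the same assay. The change from compound 3 to compound 4 `Nc1ncnc2c1ncn2CC(O)C(=O)OC1CCCCC1` is cyclohexyl in place of methyl on an oxygen next to a carbonyl group. For the measured compounds named here, two measured steps bear on this change: an at least 10-fold lower number from compound 1 to compound 2 (1.00 log units; beyond the scatter) and an at least 10-fold higher number from compound 2 to compound 3 (1.00 log units; beyond the scatter), both beyond the scatter, whereas a step that the two limits leave unreadable from compound 1 to compound 3. In both readable steps the number fell when furan-2-yl, rather than methyl or hydrogen, stood on the saturated chain carbon bound to the oxygen next to the carbonyl group, and the limit of > 400 ug/mL in this assay, at which 2 of the 3 values shown sit, means the starting point for compound 3 can only move downward or stay where it is. Compound 4 is therefore expected to show an at least 2.0-fold lower number from compound 3 to compound 4 (0.30 log units; that floor lies within the scatter), a decrease of modest size. The estimate for compound 4 is 200 ug/mL, with a range from 60 ug/mL to 400 ug/mL.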

Compound 4, minimum cytotoxic concentration: 100 ug/mL
Estimate against measurement, compound 4: 2.0-fold (0.30 log units) above, and the stated range covers the measured number.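

In this assay, the steps of an at least 4.0-fold lower number from compound 3 to compound 4 (0.60 log units; beyond the scatter) and an at least 4.0-fold lower number from compound 1 to compound 4 (0.60 log units; beyond the scatter) show that a lower number at this position does not depend on a furan-2-yl ring, since cyclohexyl on an oxygen next to a carbonyl group lowers it as well. The two ring-bearing groups are not interchangeable, however: the change to cyclohexyl from (furan-2-yl)methyl gives a 2.5-fold higher number from compound 2 to compound 4 (0.40 log units; beyond the scatter). The true size of the drop from methyl or ethyl remains unknown, because compound 1 and compound 3 both stand at a limit of the assay: the limit of > 400 ug/mL in this assay, at which 2 of the 4 values shown sit.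

The compounds shown leave open whether the ring itself matters or only the number of carbons, which a longer open chain such as hexyl on the same oxygen would help to separate. They also leave open how a free carboxylic acid would behave at this position.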